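The compounds below may be only part of what the source reports. "The series", "measured", "known", "first", "only" and "open" are said of these compounds alone.

Compound 1 `CC(C)(C)NCc1c(C(=O)O)nn(-c2ccccc2)c1-c1ccc(Br)cc1`: > 585000 nM
Compound 2 `CC(C)(C)NCc1c(C(=O)O)nn(-c2ccccc2)c1-c1ccccc1`: > 716000 nM

In a functional assay on PC-3 cells (Homo sapiens) for inhibition, read by sulforhodamine B assay, with a stated time of 48 h (a lower number here means a stronger inhibitor of growth, a higher number a weaker inhibitor of growth), compound 2 gives > 716000 nM, which is a limit and not a number. Compound 1 gives > 585000 nM, which is also a limit. Among the measured compounds shown here, compound 2 therefore has no measured number to stand on, and neither does the only other compound tested.

Compound 3 `COc1ccc(-c2c(CNC(C)(C)C)c(C(=O)O)nn2-c2ccccc2)cc1` takes methoxy in place of hydrogen on an aromatic carbon, turning phenyl into 4-methoxyphenyl: methoxy in place of hydrogen on an aromatic carbon. For the measured compounds named here, the one measured step that bears on this, a step that the two limits leave unreadable from compound 1 to compound 2, also changes a group on an aromatic carbon, but its size cannot be read. It supports no direction in this assay, so no step beyond the scatter is expected. The estimated change is an at least 1.1-fold lower number from compound 2 to compound 3 (0.04 log units; that floor lies within the scatter). For compound 3 the estimate is 650000 nM, with an expected range of 350000 nM to 800000 nM, and only a limit may be reported again.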

Compound 3, concentration for 50% growth inhibition: > 659000 nM
Compound 3 gave a limit, no number (the forecaster's own chance of this, stated with the estimate: 85%); at least 1.0-fold (0.00 log units) between middle value and limit.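

In this assay compound 3 gives > 659000 nM, which is a limit and not a number. Among the compounds shown here, no step among compound 1, compound 2 and compound 3 can be read. The compounds shown leave open whether hydrogen, bromo or methoxy on the aromatic carbon makes any difference to growth inhibition.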